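The source may report more compounds than this note shows. Statements on the series, on what has been measured and on what is new or still open speak of the compounds shown alone.

Measured compounds:
compound 1, `CN(C)c1cc2[nH]c(C3CCCCC3)nc2cc1NC(=O)OCC(F)(F)F`, > 100 ug/mL
compound 2, `CCN(CC)c1cc2[nH]c(C3CCCCC3)nc2cc1NC(=O)c1ccc(OC(F)F)cc1`, > 100 ug/mL

Both values come from an ADME assay on Vero cells (Chlorocebus sabaeus) for cytotoxicity, read by resazurin assay, with a stated time of 3 days; a lower number here means a stronger inhibitor, a higher number a weaker inhibitor. Compound 1 gives no number but a limit of the assay, > 100 ug/mL. Compound 2 likewise reaches only a limit, > 100 ug/mL. In this assay compound 2 thus stands at the limit of > 100 ug/mL in this assay, at which 2 of the 2 values shown sit. For the measured compounds named here, no step between two measured compounds differing in a single place is available, so the effect of a single change on this read-out is unknown from the measured pair.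

Compound 3, `CN(C)c1cc2[nH]c(C3CCCCC3)nc2cc1NC(=O)c1ccc(OC(F)F)cc1`, is not yet tested. It differs from compound 2 in one place: dimethylamino in place of diethylamino on an aromatic carbon. Compound 1 carries the same dimethylamino group and in this assay compound 1 sits at its limit. Compound 3 is therefore expected at 150 ug/mL, within 80 ug/mL to 300 ug/mL. The expected step that the limit leaves unreadable from compound 2 to compound 3 is none beyond the scatter, with a limit the most likely report.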

Compound 3, half-maximal inhibitory concentration: > 100 ug/mL
Compound 3 gave a limit, no number; the forecaster's own chance of this, stated with the estimate: 85%; the middle value does not contradict the limit.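

In this assay, for the compounds shown here, compound 3, like compound 1 and compound 2, gives only a limit of the assay, so no step from compound 1 or compound 2 to compound 3 can be read: the limit of > 100 ug/mL in this assay, at which 3 of the 3 values shown sit. The compounds shown leave open whether dimethylamino in place of diethylamino, or 4-(difluoromethoxy)phenyl in place of 2,2,2-trifluoroethoxy, changes this read-out at all.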